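Thioether in Place of Ether on the Shared Core

The source may hold more compounds than are shown below. What is called first, only, known or untested is meant among the compounds shown, and "the series" means these compounds.

Compound 1 `Nc1cc(N)c2nc(-c3ccccc3)c(Oc3ccc(Cl)c(Cl)c3)nc2c1`: in a functional assay on TK-10 cells (Homo sapiens) for inhibition, read by sulforhodamine B assay, with a stated time of 48 h (on this read-out lower numbers stand for higher toxicity in this test and higher numbers for lower toxicity in this test), compound 1 gives < 100000 nM, a limit of the assay.
Compound 2 `Nc1cc(N)c2nc(-c3ccccc3)c(Oc3ccc(F)cc3)nc2c1`: in this assay compound 2 gives 64600 nM.
Compound 3 `COc1cc(CNc2nc3cc(N)cc(N)c3nc2-c2ccccc2)cc(OC)c1OC`: in this assay compound 3 gives < 50200 nM, again a limit of the assay.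

Compound 1 thus stands only at a limit, and one further value shown, that of compound 3, is a limit as well; only compound 2 carries a number. Among the measured compounds shown here, the single measured step, a step that the limit leaves unreadable from compound 1 to compound 2, cannot be read in size. Compound 4 `Nc1cc(N)c2nc(-c3ccccc3)c(Sc3ccc(Cl)c(Cl)c3)nc2c1` differs from compound 1 by (3,4-dichlorophenyl)sulfanyl in place of 3,4-dichlorophenoxy on an aromatic carbon. For the measured compounds named here, no measured step touches an exchange of this kind, so nothing supports an expected change beyond the scatter. Compound 4 is therefore estimated at 90000 nM, between 30000 nM and 250000 nM, a step that the limit leaves unreadable from compound 1 to compound 4 that is expected to stay within the scatter.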

Compound 4, concentration lethal to 50% of the cells: 53700 nM
Estimate against measurement, compound 4: 1.7-fold (0.22 log units) above; measured number inside the range.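

With (3,4-dichlorophenyl)sulfanyl on this aromatic carbon next to the ring nitrogen, compound 4 gives a measured number where compound 1 gives only a limit. Against the 4-fluorophenoxy group of compound 2, the exchange is a 1.2-fold lower number from compound 2 to compound 4 (0.08 log units; within the scatter), so this position carries the sulfur-linked group with no change in this assay beyond the scatter. The step from compound 1 cannot be read, since that value is a limit: the limit of < 100000 nM in this assay, at which 1 of the 4 values shown sits.

The compounds shown leave open what the oxygen-to-sulfur exchange does when measured against a number. They also leave open whether an amine or a carboxylic acid at this carbon would move the read-out beyond the scatter.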